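A Sulfonamide Gives Way to a Fluorinated Benzyl

A few compounds are considered here, and "the series" means these few. Any claim that something is new, unique, unknown or untested is made for them only; others in the source may bear on it.

Of the compounds shown here, two sharing one core have been tested in an ADME assay on Huh-7 cells (Homo sapiens) for cytotoxicity; a higher number here means a weaker inhibitor of growth, a lower number a stronger inhibitor of growth. Compound 1, `COc1cc2c(=O)c(C(=O)c3ccc(C)cc3)cn(CCCc3ccccc3)c2cc1OC`, came back as "not active" (no number reported), with no number attached. Compound 2, `COc1cc2c(=O)c(C(=O)c3ccc(C)cc3)cn(Cc3ccc(S(N)(=O)=O)cc3)c2cc1OC`, gives > 25000 nM, and this reading is a limit of the assay rather than a measured number. Compound 2 thus stands at the edge of what the assay reports, as the limit of > 25000 nM in this assay, at which 1 of the 2 values shown sits, shows.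

Compound 3, `COc1cc2c(=O)c(C(=O)c3ccc(C)cc3)cn(Cc3ccc(C(F)(F)F)cc3F)c2cc1OC`, is the next step: 2-fluoro-4-(trifluoromethyl)phenyl in place of 4-sulfamoylphenyl on a saturated chain carbon bound to an aromatic nitrogen. Going by the values given here, no step between two compounds with single numbers exists here, so the size of this change can only be expected, not read off. With compound 2 resting at the limit, the step expected in this assay is a number no higher from compound 2 to compound 3 (the limit leaves the size open), which is to say little or none beyond the scatter, although a shift toward stronger growth inhibition is possible and cannot be excluded from two readings alone. The estimate for compound 3 is 25000 nM, within a range from 8000 nM to 60000 nM, with a fair chance that only a limit is reported once more.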

Compound 3, concentration for 50% growth inhibition: > 25000 nM
Compound 3: only a limit was reported; the forecaster's own chance of this, stated with the estimate: 60%; the middle value lies on the limit itself.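

Going by these compounds alone, compound 2 and compound 3 both come back from this assay as limits rather than numbers, so no step between them can be read: the limit of > 25000 nM in this assay, at which 2 of the 3 values shown sit.

What stays open is how strongly any of the compounds shown inhibits growth, and whether 2-fluoro-4-(trifluoromethyl)phenyl and 4-sulfamoylphenyl differ at all in this respect.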